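The compounds below may be only part of what the source reports. "The series", "measured", "known", "first", "only" and "open" are said of these compounds alone.

Of the compounds shown here, three have so far been read in a physicochemical assay for lipophilicity, read by HPLC, at pH 2 (on this read-out lower numbers stand for lower lipophilicity and higher numbers for higher lipophilicity), as a measure of lipophilicity. There compound 1 `CCCC1CCCCN1C(=O)c1cccc(-c2cccc(-n3ncc(C(=O)O)c3C3CC3c3cccnn3)c2)c1` gives 2.9 and compound 3 `CCCC1CCCCN1C(=O)c1cccc(-c2cccc(-n3ncc(C(=O)O)c3C3CC3c3ccccn3)c2)c1` gives 3.1 as its reading. Compound 2 `O=C(O)c1cnn(-c2cccc(-c3cccc(C(=O)N4CCCCC4)c3F)c2)c1C1CC1` gives 2.3 as the lowest of the three, beyond the scatter from both of the others.

Compound 4 `O=C(O)c1cnn(-c2cccc(-c3cccc(C(=O)N(CC4CC4)CC4CC4)c3F)c2)c1C1CC1` keeps everything in compound 2 except one group, with bis(cyclopropylmethyl)amino in place of piperidin-1-yl on a carbonyl carbon. Counted out, the difference is bis(cyclopropylmethyl)amino in place of piperidin-1-yl on a carbonyl carbon and nothing else changes.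

For the measured compounds named here, no step at this carbonyl carbon has been measured. Going by the values given here, the one measured single-place step, a number 0.20 log units higher from compound 1 to compound 3 (within the scatter) in this assay for this pair, concerns pyridin-2-yl in place of pyridazin-3-yl on a saturated ring carbon, so it sets no size for the present change. Compound 1 and compound 3 differ from compound 2 in more than one place, which leaves their values only a loose guide.

Even so, with a larger group entering and compound 3 standing at 3.1 on this scale, a rise beyond the scatter is expected in this assay for this change. The expected size is a number 0.60 log units higher from compound 2 to compound 4 (beyond the scatter) in this estimate. For compound 4 the estimated value is 2.9 with an expected range from 2.5 to 3.3 in the measurement still to come.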

Compound 4, distribution coefficient: 3.5
For compound 4 the middle estimate is 0.60 log units below the measured one; measured number above the stated range.
By their numbers in this assay, from the lowest: compound 2; then compounds 1 and 3 (each within the scatter of the next); then compound 4.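

In this assay, the group on this carbonyl carbon proves able to move the reading by a large amount, with the number a number 1.20 log units higher from compound 2 to compound 4 (beyond the scatter) when bis(cyclopropylmethyl)amino stands in place of piperidin-1-yl. For the compounds shown here, the only earlier step, a number 0.20 log units higher from compound 1 to compound 3 (within the scatter), lay within the scatter and concerned a saturated ring carbon, so this is the first sign of how much a change at the carbonyl carbon can matter on this scale. The change takes out one six-membered non-aromatic ring with 1 hetero atom and brings in 2 three-membered non-aromatic rings of carbon only, along with more heavy atoms, but no measurement at hand bears on what lies behind the size of the step.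

The compounds shown leave open whether the step depends on the cyclopropyl rings or would also appear with an open-chain group such as dipropylamino on the same carbonyl carbon. They also leave open how a ring with an oxygen atom, such as morpholin-4-yl, would read there, and whether a step of this size would recur on the core of compound 1.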